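This account rests on a few compounds, and the source may have more. Where it says the series, first, only, none or still open, it means among the compounds named here.

Measured compounds:
compound 1, `S=C(N/N=C/c1ccc(Oc2ccc3ccccc3c2)cc1)Nc1ccc(Cl)cc1`, 6.96
compound 2, `S=C(N/N=C/c1ccc(Oc2ccc(Br)cc2)cc1)Nc1ccc(Cl)cc1`, 6.37

In a physicochemical assay for lipophilicity, in phosphate buffer, measured as octanol-water partition, with a stated time of 24 h (on this read-out higher numbers stand for higher lipophilicity and lower numbers for lower lipophilicity), compound 2 stands lowest of the two numbers; its nearest neighbour is compound 1, which gives 6.96, a gap beyond the scatter. Going by the values given here, the single measured step, a number 0.59 log units lower from compound 1 to compound 2 (beyond the scatter), is the only one that touches the group on the oxygen on the aromatic ring, and it is modest and downward.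

Compound 3, `Cc1cc(Oc2ccc(/C=N/NC(=S)Nc3ccc(Cl)cc3)cc2)ccc1Cl`, is not yet measured in this assay. It differs from compound 2 in one place: 4-chloro-3-methylphenyl in place of 4-bromophenyl on an oxygen on an aromatic ring. This is not the same exchange as the measured step, so that step bears on it only as a guide to the size a change at this position can give, not its direction. A step of roughly the measured size, here upward, is expected for compound 3, a number 0.38 log units higher from compound 2 to compound 3 (beyond the scatter). Compound 3 is therefore estimated at 6.75 in this assay, within the range 6.35 to 7.15.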

Compound 3, partition coefficient: 6.59
The estimate for compound 3 lay 0.16 log units above the measured number, and the stated range covers the measured number.
By their numbers in this assay, from the lowest: compounds 2 and 3 (each within the scatter of the next); then compound 1.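

In this assay, going by these compounds alone, 4-chloro-3-methylphenyl in place of 4-bromophenyl on an oxygen on an aromatic ring gives a number 0.22 log units higher from compound 2 to compound 3 (within the scatter), so at this position the exchange of bromine for chlorine together with the added methyl yields no step that stands clear of the scatter. The exchange of the naphthalen-2-yl group, by contrast, now has a second reading, a number 0.37 log units lower from compound 1 to compound 3 (beyond the scatter), so compound 2 and compound 3, which each carry one six-membered aromatic ring of carbon only at this place, both stand apart from compound 1, and neither goes against this within the three compounds. Nothing measured on these compounds offers an explanation for these numbers.

The compounds shown do not separate the chlorine from the methyl, as each of the two changes occurs only together with the other in compound 3. They also leave open what an amine, a carboxylic acid or a longer alkyl chain on the phenyl ring would do at this position, since all three groups shown are aromatic and carry no such function.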